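Swapping the amide cap on a shared core

The source may hold more compounds than are shown below. What is called first, only, known or untested is meant among the compounds shown, and "the series" means these compounds.

Compound 2 `COc1cccc(C(=O)N(C)c2ccc3[nH]c(-c4n[nH]c5ccccc45)cc3n2)c1` gives 9010 nM in a functional assay on KB cells (Homo sapiens) for antiproliferative activity, read by MTT assay, with a stated time of 72 h; a higher number here means a weaker inhibitor, a lower number a stronger inhibitor. Among the measured compounds shown here, that is the higher of the two numbers measured, yet its only neighbour, compound 1 `CN(C(=O)CCc1ccccc1)c1ccc2[nH]c(-c3n[nH]c4ccccc34)cc2n1`, sits close: compound 1 gives 7380 nM, and the step of a 1.2-fold higher number from compound 1 to compound 2 (0.09 log units; within the scatter) is within the scatter. Compound 3 `CN(C(=O)c1ccco1)c1ccc2[nH]c(-c3n[nH]c4ccccc34)cc2n1` carries furan-2-yl in place of 3-methoxyphenyl on a carbonyl carbon. For the measured compounds named here, the one measured step, also an exchange of the group on the carbonyl carbon, stayed within the scatter, so no step beyond the scatter is expected in this assay. Compound 3 is therefore estimated at 9000 nM, with a range of 4500 nM to 18000 nM, an expected step of a 1.0-fold lower number from compound 2 to compound 3 (0.00 log units; within the scatter).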

Compound 3, half-maximal inhibitory concentration: 19400 nM
Compound 3: the middle estimate sits 2.2-fold (0.33 log units) below what was measured, outside the stated range (above it).
By their numbers in this assay, from the lowest: compounds 1 and 2 (each within the scatter of the next); then compound 3.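

In this assay furan-2-yl on the carbonyl carbon gives a 2.2-fold higher number from compound 2 to compound 3 (0.33 log units; beyond the scatter) and also a 2.6-fold higher number from compound 1 to compound 3 (0.42 log units; beyond the scatter) in comparison with phenethyl. These modest steps show that the group at this place can move the number, which the exchange of phenethyl for 3-methoxyphenyl did not show. Nothing available explains this shift. The compounds shown leave open whether any group here, such as a pyridine ring or a longer chain ending in an amine, would give a lower number than compound 1 and compound 2 rather than a higher one.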